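From 3-nitrophenyl to 2-chlorophenyl on a shared core

The source may report more compounds than this note shows. Statements on the series, on what has been measured and on what is new or still open speak of the compounds shown alone.

In a functional assay on L1210 cells (Mus musculus) for antiproliferative activity (on this read-out higher numbers stand for weaker inhibition and lower numbers for stronger inhibition), compound 1 (`COc1cc(C(=O)c2sc(-c3ccc(I)cc3)cc2N)cc(OC)c1OC`) with 4-iodophenyl stands at 400 nM while compound 2 (`COc1cc(C(=O)c2sc(-c3cccc([N+](=O)[O-])c3)cc2N)cc(OC)c1OC`) with 3-nitrophenyl stands at 11 nM as the lower of the two numbers. Going by the values given here, the only measured step is a 36-fold lower number from compound 1 to compound 2 (1.56 log units; beyond the scatter) and it lies well beyond the scatter. Compound 3 (`COc1cc(C(=O)c2sc(-c3ccccc3Cl)cc2N)cc(OC)c1OC`) has not yet been measured. It carries 2-chlorophenyl in place of 3-nitrophenyl on an aromatic carbon. The measured step bears on this change since it falls at the same place, and it shows that swapping the group there can move the number a long way. It involves neither a 2-chlorophenyl group nor any direct comparison with one, so it sets only a rough scale. With compound 2 at the low end of the two numbers (11 nM), a rise is more likely than a further fall. Expected, then, is a 9.1-fold higher number from compound 2 to compound 3 (0.96 log units; beyond the scatter) in this assay toward weaker inhibition, of moderate size. For compound 3 the estimate is 100 nM with an expected range (15 nM to 700 nM).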

Compound 3, half-maximal inhibitory concentration: 20 nM
Beside the measured number, compound 3's estimate is 5.0-fold (0.70 log units) above it; low and high end bracket the measured number.
By their numbers in this assay, from the lowest: compounds 2 and 3 (each within the scatter of the next); then compound 1.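

In this assay, the step (a 1.8-fold higher number from compound 2 to compound 3 (0.26 log units; within the scatter)) shows that a low number at this carbon, next to the ring sulfur, is not tied to 3-nitrophenyl: 2-chlorophenyl, which counts 0 hydrogen-bond acceptors against 2 for the group it replaces, gives a number within the scatter of it. The second step (a 20-fold lower number from compound 1 to compound 3 (1.30 log units; beyond the scatter)) shows that compound 1, with 4-iodophenyl, now stands apart from both other compounds, so the large gap first seen with 3-nitrophenyl is not special to that group. Nothing further is available to explain these numbers.

Since 4-iodophenyl and 2-chlorophenyl differ both in the halogen and in where it sits on the phenyl ring, the compounds shown cannot say which of the two goes with the weaker inhibition of compound 1. From the compounds shown here alone, how 4-chlorophenyl, 2-iodophenyl or plain phenyl would stand at this carbon remains open, and with it whether the low numbers need any substituent on the phenyl ring at all.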